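Swapping a piperazine for a thiazole on a shared core

The compounds below may be only part of what the source reports. "The series", "measured", "known", "first", "only" and "open" are said of these compounds alone.

Three compounds from a single series have been examined in a physicochemical assay for solubility; a higher number here means a more soluble compound, a lower number a less soluble compound. Compound 1, `Cn1nccc1-c1cc(C(F)(F)F)ccc1[C@H]1CCOc2cc(S(=O)(=O)Nc3ccncn3)ccc21`, gives 1180000 nM. Compound 2, `O=S(=O)(Nc1nccs1)c1ccc2c(c1)OCC[C@@H]2c1ccc(C(F)(F)F)cc1N1CCNCC1`, gives 288000 nM. Compound 3, `Cc1ccc(-c2cc(C(F)(F)F)ccc2[C@H]2CCOc3cc(S(=O)(=O)Nc4ncc(F)cn4)ccc32)cn1`, gives 225000 nM. Of these three numbers compound 2 holds the second highest; its nearest neighbour is compound 3, whose value sits within the usual scatter of compound 2, while compound 1 stands beyond the scatter above it.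

Compound 4, `O=S(=O)(Nc1nccs1)c1ccc2c(c1)OCC[C@@H]2c1ccc(C(F)(F)F)cc1-c1nccs1`, has not yet been measured. It differs from compound 2 in one place: 1,3-thiazol-2-yl in place of piperazin-1-yl on an aromatic carbon. Within the data shown here, no directly comparable pair has been measured, so the expected size of the step rests on the values alone. Because compound 3 gives 225000 nM and compound 2 gives 288000 nM, an aromatic ring at this position need not move the number far; still, the expectation is for a modest fall for compound 4, with a step of a 2.4-fold lower number from compound 2 to compound 4 (0.38 log units; beyond the scatter). Compound 4 is therefore estimated at 120000 nM, in a range from 40000 nM to 350000 nM.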

Compound 4, solubility: 15000 nM
Compound 4: the middle estimate sits 8.0-fold (0.90 log units) above what was measured; the measured number lies below the stated range.
By their numbers in this assay, from the lowest: compound 4; then compounds 3 and 2 (each within the scatter of the next); then compound 1.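

In this assay, the group on this aromatic carbon of the shared core matters a great deal: 1,3-thiazol-2-yl in place of piperazin-1-yl gives a 19-fold lower number from compound 2 to compound 4 (1.28 log units; beyond the scatter) as a large step. Among these compounds, this is the first change in the set that can be read on its own, since the earlier compounds differ from one another in more than one place. Nothing measured here accounts for the size of this step.

A single step cannot separate what leaving piperazin-1-yl does from what entering 1,3-thiazol-2-yl does, as both happen at once. The same core carrying a morpholine or a dimethylamino group at this position would show whether other non-aromatic amines stay close to compound 2 or fall towards compound 4.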